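From compound 1 to compound 4: adding a nitro group

This account rests on a few compounds, and the source may have more. Where it says the series, first, only, none or still open, it means among the compounds named here.

Three compounds have been measured so far in a functional assay on NCI-H460 cells (Homo sapiens) for inhibition, read by MTT assay, with a stated time of 24 h, tested at 0.1 ug/mL (a higher number here means more inhibition of growth at the concentration tested, a lower number less inhibition of growth), as follows:

compound 1 `O=C(CCCCC(S)CCS)Nc1ccccc1` gives 5.5%
compound 2 `O=C(CCCCC(S)CCS)Nc1cccc(Cl)c1` gives 9.78%
compound 3 `Cc1cccc(NC(=O)CCCCC(S)CCS)c1` gives 9.34%

Compound 1 stands together with the other two compounds. The step of a number 4.3 percentage points higher from compound 1 to compound 2 (within the scatter) and the step of a number 3.8 percentage points higher from compound 1 to compound 3 (within the scatter) do not set it apart from them, and the step of a number 0.4 percentage points lower from compound 2 to compound 3 (within the scatter) does not separate the remaining pair.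

Compound 4 `O=C(CCCCC(S)CCS)Nc1ccc([N+](=O)[O-])cc1` keeps the core of compound 1 and makes one change, (nitro in place of hydrogen on an aromatic carbon), so that nitro replaces hydrogen on an aromatic carbon, para to a large group. The two steps from compound 1 are the closest guides, since each also replaces hydrogen on an aromatic carbon, with chloro in compound 2 and methyl in compound 3. For the measured compounds named here, neither group stands para to a large group, however, and no compound carrying nitro has been measured, so the guidance is limited. With only these small steps to go on, no step beyond the scatter is expected in this assay for this change. The estimated step is a number 3.5 percentage points higher from compound 1 to compound 4 (within the scatter) and it stays small. For compound 4 the expected value is 9%, with an estimated range from 3% to 20% in this assay as the read-out.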

Compound 4, percent growth inhibition at one concentration: 5.69%
Beside the measured number, compound 4's estimate is 3.3 percentage points above it; low and high end bracket the measured number.
By their numbers in this assay, from the lowest: compounds 1, 4, 3 and 2 (each within the scatter of the next).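

In this assay the change of hydrogen to nitro gives a number 0.2 percentage points higher from compound 1 to compound 4 (within the scatter) and so adds no measurable difference. For the compounds shown here, compound 4 is the first compound here with a group para to a large group on the aromatic ring, and it shows that a group of 3 heavy atoms, with 2 hydrogen-bond acceptors and no hydrogen-bond donors, can stand at this place without moving the number beyond the scatter. The earlier steps shown here with chloro and methyl did not test this place, so all four compounds now stay together, whichever of these groups the ring carries and at either place tested. Nothing measured on these compounds bears on why the number stays where it is.

From the compounds shown here alone, it remains open whether an amine or a carboxylic acid at this same place would also stay within the scatter, or whether either would set a compound apart from compound 1 in this assay. A longer chain in place of the one carrying the amide is also untested among the compounds shown, so the part of the structure that governs the read-out remains unknown.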